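Cytotoxicity of a chlorophenyl biaryl amide in kidney cells

This account rests on a few compounds, and the source may have more. Where it says the series, first, only, none or still open, it means among the compounds named here.

In an ADME assay on HEK293 cells (Homo sapiens) for cytotoxicity, read by CellTiter-Glo and resazurin assay, with a stated time of 72 h (on this read-out lower numbers stand for an effect already at smaller amounts and higher numbers for an effect only at larger amounts of compound), compound 2 `CCOC(=O)CCCCCOc1cccc(CN(C(=O)c2ccc(-c3ccc4cc[nH]c4c3)cc2)C(C)C)c1` gives only > 26000 nM, a limit of the assay and not a number. Compound 1 `CCOC(=O)CCCCCOc1cccc(CN(C(=O)c2ccc(-c3cccc(Oc4ccccc4)c3)cc2)C(C)C)c1` likewise gives only a limit, > 19600 nM. Both values therefore sit at limits, the limit of > 19600 nM in this assay, at which 1 of the 2 values shown sits, and (the limit of > 26000 nM in this assay, at which 1 of the 2 values shown sits), and neither compound shows a measurable effect in this assay. Compound 3 `CCOC(=O)CCCCCOc1cccc(CN(C(=O)c2ccc(-c3cccc(Cl)c3)cc2)C(C)C)c1` differs from compound 2 by 3-chlorophenyl in place of 1H-indol-6-yl on an aromatic carbon. For the measured compounds named here, no measured step exists to guide the expectation, so the expected step of an at least 1.0-fold lower number from compound 2 to compound 3 (0.01 log units; that floor lies within the scatter) is none beyond the scatter. Compound 3 is estimated at 25000 nM in this assay, in a range from 10000 nM to 60000 nM, and most probably again only as a limit.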

Compound 3, half-maximal effective concentration: > 18400 nM
Compound 3 gave a limit, no number; the forecaster's own chance of this, stated with the estimate: 80%; the middle value is on the limit's open side.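

Compound 1, compound 2 and compound 3 all stand only at limits, and the steps to compound 3 from the other two cannot be read. The compounds shown leave open at what concentration any of them would act in this assay.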